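The source may report more compounds than this note shows. Statements on the series, on what has been measured and on what is new or still open speak of the compounds shown alone.

Working notes on the series in an ADME assay on MT2 cells (Homo sapiens) for cytotoxicity, read by MTT assay; a higher number here means that more compound is tolerated, a lower number that less compound is tolerated.

Compound 1 `Cc1cc(Oc2ccccc2OCCn2ccc(=O)[nH]c2=O)c2cc(C#N)[nH]c2c1` gives 1200 nM in this assay. Compound 2 `N#Cc1cc2c(Oc3ccccc3OCCn3ccc(=O)[nH]c3=O)cc(F)cn2c1` gives 40000 nM, which is the higher of the two numbers reported; the gap to compound 1 is beyond the usual scatter. Compound 3 `N#Cc1cc2c(Oc3ccc(F)cc3OCCn3ccc(=O)[nH]c3=O)cccc2o1` reaches only the limit of the assay, > 100000 nM, so no number is available for it (the limit of > 100000 nM in this assay, at which 1 of the 3 values shown sits). No pair among these three differs in only one place, so no single measured step can be read from them.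

Compound 4 `N#Cc1cc2c(Oc3ccccc3OCCn3ccc(=O)[nH]c3=O)cccn2c1` is the next compound to be measured. It differs from compound 2 in one place: hydrogen in place of fluoro on an aromatic carbon. With no measured step of this kind in the series, the expectation is a change in this assay that is no larger than the scatter, with no clear direction; if anything, a slight drift toward the lower number seen for compound 1 at 1200 nM is allowed for. For compound 4 the estimated value in this assay is 30000 nM, between 8000 nM and 100000 nM, which is expected to correspond to a step of a 1.3-fold lower number from compound 2 to compound 4 (0.12 log units; within the scatter).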

Compound 4, half-maximal cytotoxic concentration: > 100000 nM
Compound 4: only a limit was reported (the forecaster's own chance of this, stated with the estimate: 25%); middle value at least 3.3-fold (0.52 log units) away from the limit.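

Going by these compounds alone, with hydrogen in place of fluoro on an aromatic carbon, this assay gives an at least 2.5-fold higher number from compound 2 to compound 4 (0.39 log units; beyond the scatter), the first step that can be read at a single place, and it lies beyond the scatter. At this position, two atoms from the ring nitrogen, the fluoro is therefore not required for a high tolerated concentration, and of this pair the fluoro compound gives the lower number. The step is only a bound, and its full size cannot be read: the limit of > 100000 nM in this assay, at which 2 of the 4 values shown sit.

From the compounds shown here alone, how a chloro or an amine on this same aromatic carbon would read in this assay remains open. Also open, going by these compounds, is whether the same change gives a step of this direction on the cores of compound 1 and compound 3, as neither has a partner differing from it in one place.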